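The source may report more compounds than this note shows. Statements on the series, on what has been measured and on what is new or still open speak of the compounds shown alone.

Measured in a functional assay (strain AB) with Danio rerio as the target, read by microscopy, with a stated time of 1 h; a higher number here means that more compound is needed for the effect, a lower number that less compound is needed:
compound 1 `NC(=O)c1c(NC(=O)Nc2ccc(Cl)cc2)sc2c1CCN(CC1CCC1)C2`: 1360 nM
compound 2 `CC(C)CN1CCc2c(sc(NC(=O)Nc3ccc(Cl)cc3)c2C(N)=O)C1`: 4510 nM
compound 3 `CCCN1CCc2c(sc(NC(=O)Nc3ccc(Cl)cc3)c2C(N)=O)C1`: 3500 nM

Compound 3 lies close to one neighbour and apart from the other. The nearest comparison gives a 1.3-fold lower number from compound 2 to compound 3 (0.11 log units; within the scatter), while the furthest gives a 2.6-fold higher number from compound 1 to compound 3 (0.41 log units; beyond the scatter). Compound 4 `CC(C)(C)OC(=O)CCCCN1CCc2c(sc(NC(=O)Nc3ccc(Cl)cc3)c2C(N)=O)C1` carries (tert-butoxycarbonyl)methyl in place of hydrogen on a saturated chain carbon, three bonds along the chain from an amine nitrogen in a ring; cut one bond further out, this reads propyl to 4-(tert-butoxycarbonyl)butyl. The closest evidence is from changes to the same chain: a 3.3-fold higher number from compound 1 to compound 2 (0.52 log units; beyond the scatter) and a 2.6-fold higher number from compound 1 to compound 3 (0.41 log units; beyond the scatter) are modest, and a 1.3-fold lower number from compound 2 to compound 3 (0.11 log units; within the scatter) is not resolved. None of these compounds carries an ester, so the direction is weakly supported. A modest step towards a lower number is expected, with no step beyond the scatter also plausible. The estimated change is a 1.4-fold lower number from compound 3 to compound 4 (0.15 log units; within the scatter). Compound 4 is expected at 2500 nM, with an estimated range of 700 nM to 9000 nM.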

Compound 4, half-maximal effective concentration: 710 nM
Compound 4: the middle estimate sits 3.5-fold (0.55 log units) above what was measured; measured number inside the range.
By their numbers in this assay, from the lowest: compounds 4 and 1 (each within the scatter of the next); then compounds 3 and 2 (each within the scatter of the next).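

In this assay, the chain bound to the amine nitrogen in a ring accepts a much larger, ester-bearing group, with (a 4.9-fold lower number from compound 3 to compound 4 (0.69 log units; beyond the scatter)) for the change from propyl to 4-(tert-butoxycarbonyl)butyl and (a 6.4-fold lower number from compound 2 to compound 4 (0.80 log units; beyond the scatter)) against the isopropyl-bearing compound. Against the cyclobutyl-bearing compound the step is not resolved (a 1.9-fold lower number from compound 1 to compound 4 (0.28 log units; within the scatter)), so a lower number here does not depend on a compact chain end. No supporting data bear on this step. Still open, from the compounds shown here alone, is whether the step follows the tert-butyl ester or the chain length alone. A plain butyl chain, a longer chain or the free carboxylic acid would separate these readings.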